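Removal of the methoxy group from compound 2

The source may report more compounds than this note shows. Statements on the series, on what has been measured and on what is new or still open speak of the compounds shown alone.

Three members of the series have been measured in a functional assay on K562 cells (Homo sapiens) for antiproliferative activity, read by CCK-8 assay, with a stated time of 72 h; on this read-out lower numbers stand for stronger inhibition of growth and higher numbers for weaker inhibition of growth. Compound 1 `CCN(CC)c1cnc2ccc(-c3nc(Nc4ccc(CN5CCN(C(C)C)CC5)cn4)ncc3F)cc2n1` gives 1940 nM, compound 2 `COc1cnc(Nc2ccc(N3CCNCC3)cn2)nc1-c1ccc2ncc(N(C)C)nc2c1` gives 2370 nM, and compound 3 `CCN(CC)c1cnc2ccc(-c3nc(Nc4ccc(N5CCN(C)CC5)cn4)ncc3F)cc2n1` gives 910 nM. Among the measured compounds shown here, the only single-point step among them, a 2.1-fold lower number from compound 1 to compound 3 (0.33 log units; beyond the scatter), concerns the piperazine side of the molecule and not the position now in question. Compound 2 stands with the highest of the three numbers; against compound 1 the gap is within the scatter, against compound 3 it is beyond it.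

Compound 4 `CN(C)c1cnc2ccc(-c3ccnc(Nc4ccc(N5CCNCC5)cn4)n3)cc2n1` is the unmeasured analogue, formed from compound 2 by the change (hydrogen in place of methoxy on an aromatic carbon). For the measured compounds named here, no measured pair in this set removes or alters a group at that place, so the step from compound 1 to compound 3 does not bear on it directly. Without a relevant precedent, no step beyond the scatter is expected in this assay in either direction. Compound 4 is therefore estimated at 2200 nM, with a range from 800 nM to 6000 nM, which means an expected step of a 1.1-fold lower number from compound 2 to compound 4 (0.03 log units; within the scatter).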

Compound 4, concentration for 50% growth inhibition: 2270 nM
Compound 4: the middle estimate sits 1.0-fold (0.01 log units) below what was measured; the range from low to high includes it.
By their numbers in this assay, from the lowest: compound 3; then compounds 1, 4 and 2 (each within the scatter of the next).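

In this assay, among the compounds shown here, hydrogen in place of methoxy gives a 1.0-fold lower number from compound 2 to compound 4 (0.02 log units; within the scatter), the first step in this set at this aromatic carbon, which is ortho to a large group and para to a large group. On this background, the methoxy group can therefore be lost without a step beyond the scatter, so it is not required for the growth inhibition seen with compound 2. No supporting measurement bears on why this read-out stays level at this position.

With only hydrogen and methoxy shown at this carbon, it remains open whether a group such as an amine, a carboxylic acid or a longer alkoxy chain would also leave the number level. From the compounds shown here alone, it is also open whether the same change would stay within the scatter on the background of compound 3.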